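The source may hold more compounds than are shown below. What is called first, only, known or untested is meant among the compounds shown, and "the series" means these compounds.

Compound 2 `Cc1c(OCCCCOc2ccccc2C(=O)O)ccc(C(=O)CC2CCCC2)c1C` reaches 67.1% in an assay on HEK293 cells for positive allosteric modulation of metabotropic glutamate receptor 2 (Rattus norvegicus), read by thallium flux, with a stated time of 2.5 min; on this read-out higher numbers stand for larger maximal responses and lower numbers for smaller maximal responses. Among the three measured compounds it stands second highest. Compound 3 `Cc1c(OCCCCOc2ccccc2C(=O)O)ccc(C(=O)CC2CCCC2)c1O` gives 98.8%, and the step of a number 31.7 percentage points higher from compound 2 to compound 3 (beyond the scatter) separates the two. Compound 1 `COC(=O)c1ccc(OCCCCOc2ccc(C(=O)CC3CCCC3)c(O)c2C)cc1` gives 12.2%, far below both.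

Compound 4 `COC(=O)c1ccc(OCCCCOc2ccc(C(=O)CC3CCCC3)c(C)c2C)cc1` has not been measured. It differs from compound 2 in one place: 4-(methoxycarbonyl)phenyl in place of 2-carboxyphenyl on an oxygen on a saturated carbon. The same exchange has already been seen once, run the other way, as a number 86.6 percentage points higher from compound 1 to compound 3 (beyond the scatter), a large rise. That step was measured on the core of compound 3, whereas compound 2 and compound 4 share the core of compound 2, so its full size need not carry over. Still, compound 1 carries the same 4-(methoxycarbonyl)phenyl that enters here and sits at 12.2%. A large downward step is therefore expected, a number 52.1 percentage points lower from compound 2 to compound 4 (beyond the scatter), because of a number 86.6 percentage points higher from compound 1 to compound 3 (beyond the scatter). Compound 4 is estimated at 15%, with a range from 5% to 35%.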

Compound 4, largest response reached (reported as percent of maximum), in percent of the reference or control that the assay uses: 14.1%
Compound 4: the middle estimate sits 0.9 percentage points above what was measured, and the stated range covers the measured number.
By their numbers in this assay, from the lowest: compounds 1 and 4 (each within the scatter of the next); then compound 2; then compound 3.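

Replacing 2-carboxyphenyl with 4-(methoxycarbonyl)phenyl also costs much of the response on the core of compound 2, so the loss is not confined to the core of compound 3, although its size differs between the two cores: the same change on two cores in this assay, a number 86.6 percentage points higher (beyond the scatter) from compound 1 to compound 3 and a number 53 percentage points higher (beyond the scatter) from compound 4 to compound 2, 33.6 percentage points apart, beyond the scatter of two such steps

The hydroxy and methyl exchange on an aromatic carbon behaves differently too, giving a number 1.9 percentage points higher from compound 1 to compound 4 (within the scatter), whereas it separates compound 2 and compound 3 clearly: the same change on two cores in this assay, a number 31.7 percentage points higher (beyond the scatter) from compound 2 to compound 3 and a number 1.9 percentage points lower (within the scatter) from compound 4 to compound 1, 33.6 percentage points apart, beyond the scatter of two such steps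

With a number 53 percentage points lower from compound 2 to compound 4 (beyond the scatter), the group on the oxygen therefore sets the response here, and the hydroxy and methyl exchange shows its effect only alongside 2-carboxyphenyl.

The two groups differ both in their numbered ring position and as acid against methyl ester, so these compounds cannot separate those two differences. As far as these compounds go, whether an amide or a tetrazole in this place, or a longer chain, would keep the response also remains open.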